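The source may hold more compounds than are shown below. What is called first, only, known or untested is meant among the compounds shown, and "the series" means these compounds.

Of the compounds shown here, three from this series have been measured in an assay on isolated protein for binding affinity to Type-2 angiotensin II receptor (Homo sapiens); a lower number here means a stronger inhibitor, a higher number a weaker inhibitor. Compound 1 `CCCc1nc(CC)c(C(=O)OCCC[S+]([O-])c2ccccc2)n1Cc1ccc(-c2ccccc2S(=O)(=O)NC(=O)OCCC(C)C)cc1F` gives 1 nM. Going by the values given here, compound 3 `CCCc1nc(CC)c(C(=O)OCc2ccccc2OCCC(C)C)n1Cc1ccc(-c2ccccc2S(=O)(=O)NC(=O)OCCC(C)C)cc1F` gives 10 nM, and the step of a 10-fold higher number from compound 1 to compound 3 (1.00 log units; beyond the scatter) is the only single-point change measured so far. Compound 2 `CCCc1nc(CC)c(C(=O)OCc2ccccc2C(=O)c2ccccc2)n1Cc1ccc(-c2ccccc2S(=O)(=O)NC(=O)OC)cc1` gives 10 nM, level with compound 3 at the digits shown and together with it the highest of the three numbers; compound 1 sits furthest from it.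

Compound 4 `CCCc1nc(CC)c(C(=O)OCc2ccccc2C(=O)c2ccccc2)n1Cc1ccc(-c2ccccc2S(=O)(=O)NC(=O)OCCc2ccccc2)cc1` differs from compound 2 in one place: benzyl in place of hydrogen on a saturated chain carbon bound to an oxygen next to a carbonyl group. Among the compounds with values here, no measured step touches this end of the molecule; the step from compound 1 to compound 3 changes a different group and so does not bear directly on it. Compounds 1 and 3, which both carry a larger group than compound 2 at this same place, give numbers that bracket compound 2 rather than pointing one way. The expectation for compound 4 is therefore a step of a 1.7-fold lower number from compound 2 to compound 4 (0.22 log units; within the scatter) that stays within the scatter, and compound 4 is estimated at 6 nM, between 1.5 nM and 25 nM.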

Compound 4, half-maximal inhibitory concentration: 2.1 nM
Estimate against measurement, compound 4: 2.9-fold (0.46 log units) above; the range from low to high includes it.
By their numbers in this assay, from the lowest: compound 1; then compound 4; then compounds 2 and 3 (each within the scatter of the next).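

Going by these compounds alone, until now no measured step touched this end of the molecule. In this assay the change from methoxycarbonyl to phenethyloxycarbonyl gives a 4.8-fold lower number from compound 2 to compound 4 (0.68 log units; beyond the scatter) and so shows that the number responds to what sits on this saturated chain carbon, and that benzyl, with its six-membered aromatic ring, costs nothing here in place of hydrogen. No other measurement available here accounts for this step.

On these data alone, only hydrogen and benzyl are compared directly, so it stays open whether the aromatic ring or simply the greater length produces the lower number, a question that a straight hexyl chain without a ring could help answer. Also open, as far as these compounds go, is how this place responds to a group carrying an amine or a carboxylic acid at the end of the chain.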